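Trimming the amide of a urotensin receptor ligand

A few compounds are considered here, and "the series" means these few. Any claim that something is new, unique, unknown or untested is made for them only; others in the source may bear on it.

compound 1 `COc1ccc(C(=O)N[C@H]2CCN(Cc3ccc(OCCCN(C)C)cc3)C2)cc1OC` — < 10000 nM
compound 2 `CN(C)CCCOc1ccc(CN2CC[C@H](NC(=O)c3cccs3)C2)cc1` — < 10000 nM

In an assay on HEK293 cells for binding affinity to Urotensin-2 receptor (Homo sapiens), read by radioligand binding (a lower number here means a stronger inhibitor, a higher number a weaker inhibitor), compound 1 gives < 10000 nM, which is a limit of the assay and not a number. Compound 2 likewise gives only a limit, < 10000 nM. Among the measured compounds shown here, the single measured step, a step that the two limits leave unreadable from compound 1 to compound 2, is unreadable for that reason, as the limit of < 10000 nM in this assay, at which 2 of the 2 values shown sit, shows. Compound 3 `CC(=O)N[C@H]1CCN(Cc2ccc(OCCCN(C)C)cc2)C1` differs from compound 1 by methyl in place of 3,4-dimethoxyphenyl on a carbonyl carbon. For the measured compounds named here, no measured step bears on this change, so in this assay no direction can be expected with confidence. Compound 3 is estimated at 5000 nM, within 1000 nM to 30000 nM. The expected step is a step that the limit leaves unreadable from compound 1 to compound 3.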

Compound 3, inhibition constant: < 10000 nM
Compound 3: only a limit was reported (the forecaster's own chance of this, stated with the estimate: 50%); the middle value is on the limit's open side.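

No step among compound 1, compound 2 and compound 3 can be read, since each gives only a limit: the limit of < 10000 nM in this assay, at which 3 of the 3 values shown sit.

The compounds shown leave open how strongly each binds and whether the group on the carbonyl carbon matters at all.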